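The source may hold more compounds than are shown below. What is called first, only, known or untested is meant among the compounds shown, and "the series" means these compounds.

Measured so far in a functional assay on K562 cells (Homo sapiens), read by MTT assay, with a stated time of 72 h; on this read-out higher numbers stand for weaker inhibition and lower numbers for stronger inhibition:
Compound 1 `COc1nc(N)nc2c1c(-c1cc3ccccc3o1)cn2[C@@H]1O[C@H](CO)[C@@H](O)[C@H]1O` gives 14600 nM.
Compound 2 `COc1ncnc2c1c(I)cn2[C@@H]1O[C@H](CO)[C@@H](O)[C@H]1O` gives only a limit of the assay, > 20000 nM.
Compound 3 `O=c1[nH]cnc2c1c(-c1cccs1)cn2[C@@H]1O[C@H](CO)[C@@H](O)[C@H]1O` gives only a limit of the assay as well, > 20000 nM.

Compound 2 therefore stands at no number at all in this assay: its result is a limit, and it is not alone there, because of the limit of > 20000 nM in this assay, at which 2 of the 3 values shown sit. For the measured compounds named here, of the three values, only that of compound 1 is a number, and that number is itself at the weak end of the range the assay covers. Going by the values given here, nothing among the measured compounds differs from another in a single place, so no measured step can be used as a yardstick.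

The unmeasured compound 4 `COc1ncnc2c1c(-c1ccoc1)cn2[C@@H]1O[C@H](CO)[C@@H](O)[C@H]1O` is compound 2 with one change: furan-3-yl in place of iodo on an aromatic carbon. A five-membered aromatic ring takes the place of a single halogen on the core, and the two other compounds that carry an aromatic ring at that position on a shared core are compound 1 and compound 3, neither of which reaches strong inhibition.

Among the compounds with values here, with no measured step to lean on, the expected change from compound 2 to compound 4 is an at least 1.1-fold lower number from compound 2 to compound 4 (0.04 log units; that floor lies within the scatter), small and uncertain in direction. Compound 4 is estimated at 18000 nM, with a range from 6000 nM to 50000 nM, and a fair chance that this assay again reports only a limit.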

Compound 4, half-maximal inhibitory concentration: 190 nM
Beside the measured number, compound 4's estimate is 95-fold (1.98 log units) above it, and the stated range ends above it.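

In this assay, the swap of iodo for furan-3-yl on an aromatic carbon of the five-membered aromatic ring of the shared core gives an at least 100-fold lower number from compound 2 to compound 4 (2.02 log units; beyond the scatter), a large step well beyond the usual scatter. For the compounds shown here, the starting value of compound 2, > 20000 nM, is a limit of the assay and not a number, so the true size of the step stays open and only its lower bound can be read: the limit of > 20000 nM in this assay, at which 2 of the 4 values shown sit. The earlier compounds included no pair differing in one place, so this is the first evidence that the group at this position can, by itself, move the result in this assay from the limit of the assay to a clear number.

The compounds shown leave open whether this step belongs to furan-3-yl in particular or would also come with furan-2-yl, phenyl, an amine or a short alkyl chain at the same carbon. They also leave open what happens to compound 4 when its methoxy group on the shared core gives way to another group, such as methylamino.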